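The compounds below may be only part of what the source reports. "The series", "measured", "known", "first", "only" and "open" are said of these compounds alone.

In a functional assay on HepG2 cells (Homo sapiens) for cytotoxicity, read by MTT assay, with a stated time of 48 h (a higher number here means a weaker inhibitor, a lower number a stronger inhibitor), compound 3 `COCCNC(=C\C(=O)/C=C/c1ccc(O)cc1)/C=C/c1ccc(O)cc1` gives 63300 nM and compound 1 `O=C(/C=C(/C=C/c1ccc(O)cc1)NCCCO)/C=C/c1ccc(O)cc1` gives 54100 nM, so these two lie within the scatter of each other. Compound 2 `COc1cc(/C=C/C(=O)/C=C(/C=C/c2ccc(O)c(OC)c2)NCCCO)ccc1O` gives > 100000 nM, which is a limit of the assay and not a number. Compound 4 `O=C(/C=C(/C=C/c1ccc(O)cc1)NCCO)/C=C/c1ccc(O)cc1` has not yet been measured. It differs from compound 3 by hydrogen in place of methyl on an oxygen on a saturated carbon, turning 2-methoxyethyl into 2-hydroxyethyl. Within the data shown here, the one measured step that bears on this puts methoxy in place of hydroxymethyl on a saturated chain carbon, a 1.2-fold higher number from compound 1 to compound 3 (0.07 log units; within the scatter), so no step beyond the scatter is expected in this assay. The estimated change is a 1.1-fold lower number from compound 3 to compound 4 (0.04 log units; within the scatter). For compound 4 the expected value is 58000 nM, with an estimated range of 30000 nM to 100000 nM.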

Compound 4, half-maximal inhibitory concentration: 48400 nM
Compound 4: middle estimate off by 1.2-fold (0.08 log units), on the high side, within the range that was stated.
By their numbers in this assay, from the lowest: compounds 4, 1 and 3 (each within the scatter of the next). At a limit, above all of these: compound 2.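

In this assay, the direct exchange of 2-methoxyethyl for 2-hydroxyethyl gives a 1.3-fold lower number from compound 3 to compound 4 (0.12 log units; within the scatter). Hydroxy in place of hydroxymethyl on the saturated chain carbon gives a 1.1-fold lower number from compound 1 to compound 4 (0.05 log units; within the scatter). This side chain has thus been changed in two further ways, and neither step lies beyond the scatter. Going by these compounds, whether an amine, a carboxylic acid or a longer chain in place of 2-hydroxyethyl would give a step beyond the scatter remains open. Nothing measured here bears on why these steps are so small.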